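A few compounds are considered here, and "the series" means these few. Any claim that something is new, unique, unknown or untested is made for them only; others in the source may bear on it.

In a physicochemical assay for solubility, in phosphate buffer, with a stated time of 18 h, at pH 7.4 (a lower number here means a less soluble compound, a higher number a more soluble compound), compound 1 `COc1cc2ncnc(-n3nc(-c4ccccn4)nc3N)c2cc1OCc1ccccc1` gives 58000 nM. Compound 2 `COc1cc2ncnc(-n3nc(-c4ccccn4)nc3N)c2cc1OCCCNC(=O)OC(C)(C)C` gives 2000 nM, and compound 3 `COc1cc2ncnc(-n3nc(-c4ccccn4)nc3N)c2cc1OCCCNC(=O)OC(C)C` gives 18000 nM. This places compound 3 second of the three numbers, with a 3.2-fold lower number from compound 1 to compound 3 (0.51 log units; beyond the scatter) on one side and a 9.0-fold higher number from compound 2 to compound 3 (0.95 log units; beyond the scatter) on the other.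

Compound 4 `CCCCCCOC(=O)NCCCOc1cc2c(-n3nc(-c4ccccn4)nc3N)ncnc2cc1OC` has not yet been measured. Its structure departs from that of compound 3 in one place: hexyl in place of isopropyl on an oxygen next to a carbonyl group, which is hexyl in place of isopropyl on an oxygen next to a carbonyl group.

For the measured compounds named here, the most relevant measurement is a 9.0-fold higher number from compound 2 to compound 3 (0.95 log units; beyond the scatter), the only measured step that alters the group on that oxygen. Read in reverse, it pairs the added methyl of compound 2 with a lower number. The step of a 29-fold lower number from compound 1 to compound 2 (1.46 log units; beyond the scatter) replaces much more of the molecule and bears on the question less directly. Going by the values given here, no measured compound carries hexyl, so the evidence is thin and rests on a single pair.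

A modest to large drop is nevertheless expected, and the estimate is a 6.0-fold lower number from compound 3 to compound 4 (0.78 log units; beyond the scatter). Compound 4 is expected to give about 3000 nM, within an estimated range of 500 nM to 12000 nM.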

Compound 4, solubility: 1000 nM
Estimate against measurement, compound 4: 3.0-fold (0.48 log units) above; low and high end bracket the measured number.
By their numbers in this assay, from the lowest: compounds 4 and 2 (each within the scatter of the next); then compound 3; then compound 1.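

In this assay, isopropyl on this oxygen next to a carbonyl group now stands apart from two other groups rather than one: hexyl in place of isopropyl gives an 18-fold lower number from compound 3 to compound 4 (1.26 log units; beyond the scatter), in the same direction as the earlier change from isopropyl to tert-butyl. Hexyl and tert-butyl are not separated here (a 2.0-fold lower number from compound 2 to compound 4 (0.30 log units; within the scatter)), so among the three groups measured at this oxygen only isopropyl gives a distinct number. The wider change from the side chain of compound 1 gives a 58-fold lower number from compound 1 to compound 4 (1.76 log units; beyond the scatter), which leaves compound 1 the highest of the four, although this step replaces far more than the group on the oxygen.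

No measurement shown accounts for these differences. The compounds shown leave open how a shorter chain such as ethyl, a ring such as cyclohexyl or an amine at the end of the hexyl chain would read in this assay, and whether a chain longer than hexyl would remain within the scatter of compound 4.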